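This account rests on a few compounds, and the source may have more. Where it says the series, first, only, none or still open, it means among the compounds named here.

Compound 2 `Cc1cc(Cl)ccc1CC(C)C(=O)N1CCN(c2ccc(C(F)(F)F)cc2[C@@H](N)CC(C)C)CC1` holds the lowest number of the two compounds that gave a number in an assay on HEK293 cells for displacement of a labelled ligand from Melanocortin receptor 4 (Homo sapiens); a lower number here means a stronger inhibitor, a higher number a weaker inhibitor: compound 2 gives 38 nM. Its nearest neighbour is compound 1 `COc1ccc(OCC(=O)N2CCN(c3ccc(C(F)(F)F)cc3[C@@H](N)CC(C)C)CC2)cc1`, which in this assay gives 3800 nM. Compound 3 `CC(C)C[C@H](N)c1cc(C(F)(F)F)ccc1N1CCN(C(=O)CCC(N)=O)CC1` gives only a limit in this assay, not a number: compound 3 sits at > 10000 nM, which is the limit of > 10000 nM in this assay, at which 1 of the 3 values shown sits.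

Compound 4 `Cc1ccc(OCC(=O)N2CCN(c3ccc(C(F)(F)F)cc3[C@@H](N)CC(C)C)CC2)cc1` differs from compound 2 in one place: (4-methylphenoxy)methyl in place of 1-(4-chloro-2-methylbenzyl)ethyl on a carbonyl carbon. Going by the values given here, two measured steps bear on this. The step from compound 1 to compound 2 swapped a (4-methoxyphenoxy)methyl group for the 1-(4-chloro-2-methylbenzyl)ethyl group on the same carbonyl carbon and gave a 100-fold lower number from compound 1 to compound 2 (2.00 log units; beyond the scatter); the change to compound 4 runs that swap backwards, ending at a (4-methylphenoxy)methyl group that differs from the group in compound 1 only in carrying methyl instead of methoxy. The step of an at least 260-fold higher number from compound 2 to compound 3 (2.42 log units; beyond the scatter) shows that losing the 1-(4-chloro-2-methylbenzyl)ethyl group for a 2-carbamoylethyl group pushed the number out to the limit. A large step upward, beyond the scatter, is therefore expected: a 79-fold higher number from compound 2 to compound 4 (1.90 log units; beyond the scatter). Compound 4 is estimated to give 3000 nM in this assay, with a range from 900 nM to 10000 nM.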

Compound 4, inhibition constant: 4400 nM
Compound 4: the middle estimate sits 1.5-fold (0.17 log units) below what was measured; the measured number falls inside the stated range.
By their numbers in this assay, from the lowest: compound 2; then compounds 1 and 4 (each within the scatter of the next). At a limit, above all of these: compound 3.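

Methyl in place of methoxy on an aromatic carbon of the phenoxy group makes no reading difference in this assay, with a 1.2-fold higher number from compound 1 to compound 4 (0.06 log units; within the scatter), so compounds 1 and 4 stand level and this ring substituent shows no measurable effect here. The large gap to the 1-(4-chloro-2-methylbenzyl)ethyl group now appears a second time, as a 120-fold higher number from compound 2 to compound 4 (2.06 log units; beyond the scatter), which means it does not depend on the methoxy group of compound 1 alone and holds for both phenoxy-type groups shown on this carbonyl carbon. On these data alone, putting 4-methylphenoxy in place of carbamoylmethyl gives an at least 2.2-fold lower number from compound 3 to compound 4 (0.35 log units; beyond the scatter), but the true size of that step stays unknown, since compound 3 has a limit and not a number: the limit of > 10000 nM in this assay, at which 1 of the 4 values shown sits.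

The 1-(4-chloro-2-methylbenzyl)ethyl group differs from the phenoxy-type groups in several features at once, so these compounds cannot say whether its chlorine, its methyl, its branch or the missing ether oxygen carries the gap. As far as these compounds go, how a plain benzyl group, a longer chain or a chain ending in an amine or a carboxylic acid would read at this carbonyl carbon also stays open.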